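A few compounds are considered here, and "the series" means these few. Any claim that something is new, unique, unknown or untested is made for them only; others in the source may bear on it.

Measured so far:
compound 1, `CC1CCCCN1C(=S)SCc1ccc(C(=O)Nc2ccccc2N)cc1`, 45.5%
compound 2, `COc1ccc(N2CCN(C(=S)SCc3ccc(C(=O)Nc4ccccc4N)cc3)CC2)cc1`, 39.4%

Both compounds were tested in a functional assay on HeLa cells (Homo sapiens) for antiproliferative activity, read by CCK-8 assay, with a stated time of 72 h, tested at 2 uM; a lower number here means a weaker effect, a higher number a stronger effect of the compound at the concentration tested. In this assay compound 1 gives 45.5% and compound 2 gives 39.4%; the gap between them lies within the usual scatter, so compound 1 is not set apart from compound 2 on these two numbers. Going by the values given here, no step between measured compounds is given.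

Compound 3, `CN(Cc1ccncc1)C(=S)SCc1ccc(C(=O)Nc2ccccc2N)cc1`, has not yet been measured in this assay. It differs from compound 1 in one place: methyl((pyridin-4-yl)methyl)amino in place of 2-methylpiperidin-1-yl on a thiocarbonyl carbon. Since the two measured compounds, which carry different groups on the thiocarbonyl carbon, fall within the scatter of each other, the step from compound 1 to compound 3 is expected to be small as well, no larger than the scatter in either direction, with a number 5.5 percentage points lower from compound 1 to compound 3 (within the scatter) as the expected shift. Compound 3 is therefore estimated to give 40% in this assay, with a range from 25% to 57%.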

Compound 3, a percentage reported as inhibition, at one concentration (the size of the read-out at that concentration, not a potency): 29.5%
For compound 3 the middle estimate is 10.5 percentage points above the measured one; low and high end bracket the measured number.
By their numbers in this assay, from the lowest: compounds 3, 2 and 1 (each within the scatter of the next, the first and the last beyond it).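

In this assay, methyl((pyridin-4-yl)methyl)amino in place of 2-methylpiperidin-1-yl on a thiocarbonyl carbon gives a number 16 percentage points lower from compound 1 to compound 3 (beyond the scatter). Going by these compounds alone, this is the first single change at this position whose size can be read, and it shows that the group on the thiocarbonyl carbon can shift the inhibition at the tested concentration beyond the usual scatter, though only modestly. Nothing measured here accounts for the fall that accompanies this exchange of a non-aromatic ring for an aromatic one.

The compounds shown leave open whether the step follows the ring nitrogen of the pyridin-4-yl group or the open methyl-substituted amine that carries it. A benzyl(methyl)amino group would separate these two, and a plain piperidin-1-yl group would show what the methyl on the ring of compound 1 contributes.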